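From methyl to 4-chlorophenyl on the nitrogen

This account rests on a few compounds, and the source may have more. Where it says the series, first, only, none or still open, it means among the compounds named here.

Compound 1 `Cc1c(C)c2c(c(C)c1N)CC(C)(CSCCC(=O)O)O2`: 43 mg/kg
Compound 2 `CNc1c(C)c(C)c2c(c1C)CC(C)(C)O2`: 16.6 mg/kg
Compound 3 `Cc1c(C)c2c(c(C)c1Nc1ccc(Cl)cc1)CC(C)(C)O2`: not yet measured

In a functional assay on the whole organism with Mus musculus as the target (on this read-out lower numbers stand for an effect already at smaller amounts and higher numbers for an effect only at larger amounts of compound), compound 2 gives 16.6 mg/kg, the lower of the two numbers, and compound 1 gives 43 mg/kg. The gap between these two numbers lies beyond the usual scatter. Compound 3 has 4-chlorophenyl in place of methyl on a nitrogen on an aromatic ring. Among the compounds with values here, no measured pair shows a change of this kind, so the size of the step is uncertain. A moderate move toward a higher number in this assay is expected, an estimated 1.8-fold higher number from compound 2 to compound 3 (0.26 log units; within the scatter). For compound 3 the expected value is 30 mg/kg, with an estimated range of 9 mg/kg to 100 mg/kg.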

Compound 3, dose for 50% inhibition: > 50 mg/kg
Compound 3 ended at the assay's limit; the forecaster's own chance of this, stated with the estimate: 15%; middle value at least 1.6-fold (0.22 log units) from the limit.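

In this assay compound 3 gives > 50 mg/kg, which is a limit and not a number. Placing 4-chlorophenyl in place of methyl on a nitrogen on an aromatic ring gives an at least 3.0-fold higher number from compound 2 to compound 3 (0.47 log units; beyond the scatter), so this nitrogen does not accept every group without a loss in this read-out. How large the step really is stays unknown, because the value stops at the limit: the limit of > 50 mg/kg in this assay, at which 1 of the 3 values shown sits.

From the compounds shown here alone, it remains open whether the ring or its chlorine carries this step. An unsubstituted phenyl or an ethyl on this nitrogen could separate these possibilities.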